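Trifluoromethyl step on the aryl amide series

The source may report more compounds than this note shows. Statements on the series, on what has been measured and on what is new or still open speak of the compounds shown alone.

Measured so far:
compound 1 `CN(C)CCC(NC(=O)CCc1ccccc1)c1ccc(Cl)cc1`: 139%
compound 2 `Cc1ccc(C(CCN(C)C)NC(=O)/C=C/c2ccccc2)cc1`: 97%
compound 3 `CN(C)CCC(NC(=O)CCc1ccc(C(F)(F)F)cc1)c1ccc(Cl)cc1`: 73%

In a functional assay on NIH3T3 cells for agonist activity at Urotensin-2 receptor (Homo sapiens), with a stated time of 5 days (a lower number here means a smaller maximal response, a higher number a larger maximal response), compound 1 gives 139%, compound 3 gives 73% and compound 2 gives 97%. For the measured compounds named here, the one counted change within the set is trifluoromethyl in place of hydrogen on an aromatic carbon, and it moves the response by a number 66 percentage points lower from compound 1 to compound 3 (beyond the scatter). The difference between the core of compound 1 and the core of compound 2 is not broken down here.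

Compound 4 `Cc1ccc(C(CCN(C)C)NC(=O)/C=C/c2ccc(C(F)(F)F)cc2)cc1` is not yet measured in this assay. It arises from compound 2 by trifluoromethyl in place of hydrogen on an aromatic carbon, the same change that carried compound 1 to compound 3. A drop of similar direction is expected from compound 2 to compound 4, about a number 52 percentage points lower from compound 2 to compound 4 (beyond the scatter), resting on the step of a number 66 percentage points lower from compound 1 to compound 3 (beyond the scatter), though the cores differ and that step is a single observation. For compound 4 the expected value in this assay is 45%, with a range from 15% to 85%.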

Compound 4, largest response reached (reported as efficacy), in percent of the reference or control that the assay uses: 96%
The estimate for compound 4 lay 51 percentage points below the measured number; measured number outside the range, above it.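

Carried onto the core of compound 2, trifluoromethyl in place of hydrogen on an aromatic carbon gives, in this assay, a number 1 percentage points lower from compound 2 to compound 4 (within the scatter) and does not repeat the earlier drop. The same change therefore gives different steps on these two cores: the same change on two cores in this assay, a number 66 percentage points lower (beyond the scatter) from compound 1 to compound 3 and a number 1 percentage points lower (within the scatter) from compound 2 to compound 4, 65 percentage points apart, beyond the scatter of two such steps. The step seen on the core of compound 1 cannot be carried over as a fixed amount, but with one pair per core the data do not show which difference between the cores goes with the gap, nor how the change behaves on any other core.

The compounds shown leave open whether a nitrile or a methoxy group in the same place would follow either pair. Also open, from the compounds shown here alone, is whether a primary amine in place of the dimethylamino group would alter the gap between the two steps.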